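Cyclopropane anilides with trimethoxyphenyl: ester versus alcohol

The source may hold more compounds than are shown below. What is called first, only, known or untested is meant among the compounds shown, and "the series" means these compounds.

Measured so far:
compound 1 `CCOC(=O)[C@@]1(C(=O)Nc2ccccc2)C[C@@H]1c1cc(OC)c(OC)c(OC)c1`: > 100000 nM
compound 2 `COc1cc([C@H]2C[C@@]2(CO)C(=O)Nc2ccccc2)cc(OC)c1OC`: > 100000 nM
compound 3 `COc1cc([C@H]2C[C@]2(CO)C(=O)Nc2ccccc2Cl)cc(OC)c1OC`: 40700 nM

In a functional assay on QGY cells (Homo sapiens) for cytotoxicity, read by MTT assay, with a stated time of 48 h (on this read-out higher numbers stand for weaker inhibition and lower numbers for stronger inhibition), compound 1 gives only a limit of the assay, > 100000 nM. Compound 2 likewise gives only a limit, > 100000 nM. Going by the values given here, compound 3 is the one compound with a number, 40700 nM. The change from compound 2 to compound 1 is ethoxycarbonyl in place of hydroxymethyl on a saturated ring carbon; its step that the two limits leave unreadable from compound 2 to compound 1 cannot be read, because the limit of > 100000 nM in this assay, at which 2 of the 3 values shown sit, covers both ends. How the core of compound 3 differs from that of compound 2 is not broken down here.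

Compound 4 `CCOC(=O)[C@]1(C(=O)Nc2ccccc2Cl)C[C@@H]1c1cc(OC)c(OC)c(OC)c1` is not yet measured. It carries the same change, (ethoxycarbonyl in place of hydroxymethyl on a saturated ring carbon). No readable step exists for this change; compound 3 alone supplies a number, 40700 nM, so the expected step of a 1.5-fold higher number from compound 3 to compound 4 (0.17 log units; within the scatter) is taken as small. A reading at the limit of the assay for compound 4 remains quite possible. For compound 4 the estimate is 60000 nM, expected between 15000 nM and 200000 nM.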

Compound 4, half-maximal inhibitory concentration: 34700 nM
Compound 4: the middle estimate sits 1.7-fold (0.24 log units) above what was measured, and the stated range covers the measured number.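

In this assay, ethoxycarbonyl in place of hydroxymethyl on a saturated ring carbon gives a 1.2-fold lower number from compound 3 to compound 4 (0.07 log units; within the scatter), so this pair cannot be told apart on this read-out. On the other core, compound 1 and compound 2 each give only a limit, and that step cannot be read because neither end carries a number: the limit of > 100000 nM in this assay, at which 2 of the 4 values shown sit.

The change therefore has one readable result, on one core, and this neither shows nor rules out that it carries over to another core.

As far as these compounds go, it remains open how a carboxylic acid or an amine on the same saturated ring carbon would read beside compound 3. From the compounds shown here alone, a longer chain in place of the ethyl of ethoxycarbonyl is equally open.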